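Carboxy to Morpholinylcarbonyl: an Expected Step

The source may report more compounds than this note shows. Statements on the series, on what has been measured and on what is new or still open speak of the compounds shown alone.

Compounds measured so far:
compound 1, `O=C(O)/C=C/c1ccncc1-c1ccc2cc[nH]c2c1`: in a functional assay on MDA-MB-231 cells (Homo sapiens) for inhibition, read by sulforhodamine B assay, with a stated time of 72 h (a higher number here means a weaker inhibitor of growth, a lower number a stronger inhibitor of growth), compound 1 gives only a limit, > 10000 nM
compound 2, `CNC(=O)/C=C/c1ccncc1-c1ccc2ccccc2c1`: compound 2 gives 8680 nM
compound 3, `O=C(/C=C/c1ccncc1-c1ccc2ccccc2c1)NC1CC1`: compound 3 gives 8420 nM

Compound 1 thus stands at the limit of > 10000 nM in this assay, at which 1 of the 3 values shown sits, a limit of the assay and not a number. Compound 4, `O=C(/C=C/c1ccncc1-c1ccc2cc[nH]c2c1)N1CCOCC1`, differs from compound 1 in one place: morpholin-4-yl in place of hydroxy on a carbonyl carbon. Among the measured compounds shown here, the only measured step, a 1.0-fold lower number from compound 2 to compound 3 (0.01 log units; within the scatter), exchanges one amide substituent for another on the other core and sits within the scatter; no measured step exchanges the hydroxy for an amide nitrogen, so none bears directly on this change. Compound 4 is nevertheless expected near the amides already measured, estimated at 8000 nM with a range of 3000 nM to 30000 nM. That estimate means an expected step of an at least 1.2-fold lower number from compound 1 to compound 4 (0.09 log units; that floor lies within the scatter).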

Compound 4, concentration for 50% growth inhibition: > 10000 nM
Compound 4: only a limit was reported; the forecaster's own chance of this, stated with the estimate: 40%; middle value at least 1.2-fold (0.09 log units) from the limit.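

In this assay compound 4 gives > 10000 nM as a limit of the assay and not a number. Among the compounds shown here, compound 1 also gives only a limit, and no step from compound 1 to compound 4 can be read: the limit of > 10000 nM in this assay, at which 2 of the 4 values shown sit. The compounds shown leave open whether morpholin-4-yl in place of hydroxy on a carbonyl carbon changes growth inhibition at all.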